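This account rests on a few compounds, and the source may have more. Where it says the series, first, only, none or still open, it means among the compounds named here.

Measured in an in vitro ADME assay on microsomes from liver (Homo sapiens) for metabolic stability; on this read-out higher numbers stand for fast clearance and lower numbers for slow clearance:
- Compound 1 `Cc1ncc(Cc2nc(-c3nc(C(F)(F)F)n[nH]3)n3ccccc23)cn1`: < 8 mL.min-1.g-1 (a limit)
- Compound 2 `Fc1ccccc1Cc1nc(-c2nc(C(F)(F)F)n[nH]2)n2cccnc12`: 17 mL.min-1.g-1
- Compound 3 `NC(=O)c1n[nH]c(-c2nc(Cc3ccccc3F)c3ccccn23)n1`: < 8 mL.min-1.g-1 (a limit)

Compound 3 stands at < 8 mL.min-1.g-1, which is a limit and not a number. This is the limit of < 8 mL.min-1.g-1 in this assay, at which 2 of the 3 values shown sit.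

Compound 4 `Fc1ccccc1Cc1nc(-c2nc(C(F)(F)F)n[nH]2)n2ccccc12` has trifluoromethyl in place of carbamoyl on an aromatic carbon. No measured pair in the series differs in one place, so the size of this step is not shown directly.

The expectation rests on compound 2, which also carries trifluoromethyl and gives 17 mL.min-1.g-1. Compound 1 also carries trifluoromethyl and goes against this, with its limit of < 8 mL.min-1.g-1.

An upward step in this assay is expected, estimated as an at least 2.2-fold higher number from compound 3 to compound 4 (0.35 log units; beyond the scatter). For compound 4 the estimated value is 18 mL.min-1.g-1, with an expected range of 8 mL.min-1.g-1 to 40 mL.min-1.g-1.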

Compound 4, intrinsic clearance in microsomes: 72 mL.min-1.g-1
The estimate for compound 4 lay 4.0-fold (0.60 log units) below the measured number; the measured number lies above the stated range.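

In this assay, the one-place change on the aromatic carbon of the five-membered ring now has a size: trifluoromethyl in place of carbamoyl gives an at least 9.0-fold higher number from compound 3 to compound 4 (0.95 log units; beyond the scatter). With trifluoromethyl held constant, 2-fluorophenyl in place of 2-methylpyrimidin-5-yl on the saturated chain carbon gives an at least 9.0-fold higher number from compound 1 to compound 4 (0.95 log units; beyond the scatter), so the number depends on both places. Both steps are open-ended, because compound 1 and compound 3 each stand at a limit: the limit of < 8 mL.min-1.g-1 in this assay, at which 2 of the 4 values shown sit.

Open, on these data alone, is how a nitrile or a carboxylic acid on that aromatic carbon would read. Also open, as far as these compounds go, is whether the two changes add up when combined.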